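A few compounds are considered here, and "the series" means these few. Any claim that something is new, unique, unknown or untested is made for them only; others in the source may bear on it.

Compound 2, `N#Cc1ccccc1CN1C(=O)N(Cc2cccc(F)c2)S(=O)(=O)n2cccc21`, is one of three compounds tested in an ADME assay on MT4 cells (Homo sapiens) for cytotoxicity, read by MTT assay, with a stated time of 5 days (on this read-out higher numbers stand for lower toxicity in this test and lower numbers for higher toxicity in this test), and for compound 2 the result is a limit of the assay, > 305000 nM. The two other compounds stand at limits as well. Compound 1, `O=C1N(Cc2ccccc2)c2cccn2S(=O)(=O)N1Cc1cccc(F)c1`, gives in this assay a limit, > 288000 nM. Compound 3, `C=CCN1C(=O)N(Cc2ccccc2)S(=O)(=O)n2cccc21`, gives in this assay a limit, > 802000 nM. Within the data shown here, the only step that can be read between measured compounds, a step that the two limits leave unreadable from compound 1 to compound 2, is one that the two limits leave unreadable, and the three limits themselves are the whole of the evidence: the limit of > 288000 nM in this assay, at which 1 of the 3 values shown sits, the limit of > 305000 nM in this assay, at which 1 of the 3 values shown sits, and (the limit of > 802000 nM in this assay, at which 1 of the 3 values shown sits).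

Compound 4, `N#Cc1ccccc1CN1C(=O)N(Cc2cccc(Cl)c2)S(=O)(=O)n2cccc21`, differs from compound 2 by chloro in place of fluoro on an aromatic carbon. Among the measured compounds shown here, no measured pair among the three compounds carries this change, so nothing read here bears on its size; what the three limits show is that none of the compounds so far has given a number in this assay. Compound 4 is therefore expected to behave the same way, and its step from compound 2 is estimated as an at least 1.0-fold lower number from compound 2 to compound 4 (0.00 log units; that floor lies within the scatter), none beyond the scatter. For compound 4 the expected value is 300000 nM, estimated to lie between 100000 nM and 900000 nM, most likely reported again only as a limit.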

Compound 4, half-maximal cytotoxic concentration: > 293000 nM
Compound 4: only a limit was reported; the forecaster's own chance of this, stated with the estimate: 85%; the middle value does not contradict the limit.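

In this assay compound 4 gives > 293000 nM, again a limit of the assay. With compound 2 also at a limit, no step can be read between compound 2 and compound 4. The compounds shown leave open whether chloro in place of fluoro alters the read-out, since none gives an actual number.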